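Glutaric acid amide extension of the nitro-chromene alkyne series

The source may report more compounds than this note shows. Statements on the series, on what has been measured and on what is new or still open speak of the compounds shown alone.

In a functional assay on 1321N1 cells for antagonist activity at P2Y purinoceptor 6 (Homo sapiens), read by fluorescence and calcium flux (on this read-out lower numbers stand for stronger inhibition and higher numbers for weaker inhibition), compound 1 `CC(C)(C)OC(=O)NCC#Cc1ccc2c(c1)C=C([N+](=O)[O-])C(C(F)(F)F)O2` gives 1200 nM. Compound 2 `CC(=O)NCC#Cc1ccc2c(c1)C=C([N+](=O)[O-])C(C(F)(F)F)O2`, which carries an acetamido group in place of the carbamate, gives 7670 nM in this assay. Among the measured compounds shown here, the single measured step, a 6.4-fold higher number from compound 1 to compound 2 (0.81 log units; beyond the scatter), is the only one of the two-compound set, so compound 2 stands with the higher of the two numbers.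

Compound 3 `O=C(O)CCCC(=O)NCC#Cc1ccc2c(c1)C=C([N+](=O)[O-])C(C(F)(F)F)O2` differs from compound 2 by 2-carboxyethyl in place of hydrogen on a saturated chain carbon bound to a carbonyl carbon. For the measured compounds named here, no measured pair covers an extension of the acyl chain itself; the only step in hand, a 6.4-fold higher number from compound 1 to compound 2 (0.81 log units; beyond the scatter), shows that a change of the group on the carbonyl carbon moved the number beyond the scatter, with the larger group giving the lower number. On that slender basis a lengthened acyl group is expected to move the number back down somewhat rather than up, though not necessarily beyond the scatter.

The estimate for compound 3 in this assay is therefore 4000 nM, within 1500 nM to 12000 nM, corresponding to an expected step of a 1.9-fold lower number from compound 2 to compound 3 (0.28 log units; within the scatter).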

Compound 3, half-maximal inhibitory concentration: 69100 nM
The estimate for compound 3 lay 17-fold (1.24 log units) below the measured number; the measured number lies above the stated range.
By their numbers in this assay, from the lowest: compound 1; then compound 2; then compound 3.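

In this assay, lengthening the acetyl group to (3-carboxypropyl)carbonyl gives a 9.0-fold higher number from compound 2 to compound 3 (0.95 log units; beyond the scatter), so the earlier link between a larger group on this carbonyl carbon and a lower number does not extend to 3-carboxypropyl. Measured against the tert-butoxy carbamate, the same change on the carbonyl carbon gives a 58-fold higher number from compound 1 to compound 3 (1.76 log units; beyond the scatter), the largest gap in the set, and group size alone therefore does not order the three compounds: compound 1 and compound 3 both carry larger groups than compound 2, yet they lie on opposite sides of it. No supporting data are available to explain the rise at this position.

The compounds shown do not separate the effect of the terminal carboxylic acid from that of the chain itself; a plain pentanoyl amide or the methyl ester of compound 3 would show which of the two goes with the higher number. Also open, going by these compounds, is how the number responds to a shorter or longer acid chain, or to a terminal amine or primary amide in place of the carboxylic acid.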